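This account rests on a few compounds, and the source may have more. Where it says the series, first, only, none or still open, it means among the compounds named here.

Measured compounds:
compound 1, `c1ccc(CCc2ccc3c(NCCCNCc4ccco4)ccnc3c2)cc1` — 23 10^-6 cm/s
compound 2, `COc1cccc(CNCCCNc2ccnc3cc(-c4ccc(C(C)(C)C)cc4)ccc23)c1O` — 237 10^-6 cm/s
compound 3, `CC(C)(C)c1ccc(-c2ccc3c(NCCCNCc4ccco4)ccnc3c2)cc1` — 237 10^-6 cm/s

In an ADME assay for permeability, using PAMPA, with a stated time of 30 min, at pH 7.4 (on this read-out lower numbers stand for lower permeability and higher numbers for higher permeability), compound 2 gives 237 10^-6 cm/s and stands level with compound 3, the two together at the top of the three numbers; compound 1 lies furthest from it, at a value that is a 10-fold higher number from compound 1 to compound 3 (1.01 log units; beyond the scatter) before compound 3. The step of no change at the digits printed from compound 2 to compound 3 (within the scatter) shows that the group on the saturated chain carbon bound to the amine nitrogen left the read-out unchanged, so the variation seen so far sits on the aromatic carbon of the core.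

Compound 4, `COc1cccc(CNCCCNc2ccnc3cc(CC(C)C)ccc23)c1O`, is not yet measured. It differs from compound 2 as follows: isobutyl in place of 4-(tert-butyl)phenyl on an aromatic carbon. Among the measured compounds shown here, the one measured step at this position, a 10-fold higher number from compound 1 to compound 3 (1.01 log units; beyond the scatter), was large and ran upward toward the 4-(tert-butyl)phenyl compound; the step from 2 to 3 does not bear on it. For the measured compounds named here, removing the 4-(tert-butyl)phenyl in favour of isobutyl is therefore expected to move the number downward, by something like a 2.6-fold lower number from compound 2 to compound 4 (0.42 log units; beyond the scatter), though no measured compound carries isobutyl and the size is uncertain. The estimate for compound 4 in this assay is 90 10^-6 cm/s, within 30 10^-6 cm/s to 240 10^-6 cm/s.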

Compound 4, apparent permeability: 23 10^-6 cm/s
Estimate against measurement, compound 4: 3.9-fold (0.59 log units) above, outside the stated range (below it).
By their numbers in this assay, from the lowest: compounds 1 and 4 (each within the scatter of the next); then compounds 2 and 3 (each within the scatter of the next).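

In this assay, isobutyl in place of 4-(tert-butyl)phenyl on the aromatic carbon gives a 10-fold lower number from compound 2 to compound 4 (1.01 log units; beyond the scatter), so a large step at this position now appears with the 2-hydroxy-3-methoxyphenyl group on the chain, as a 10-fold higher number from compound 1 to compound 3 (1.01 log units; beyond the scatter) did with furan-2-yl. In both steps the 4-(tert-butyl)phenyl compound holds the higher number, while phenethyl, which carries a ring, and isobutyl, which carries none, each stand at the lower end, so the presence of a ring in the group does not by itself decide the side of the step in these two pairs. Nothing available here explains the size of the step.

Still open, as far as these compounds go, is whether the higher level needs the whole 4-(tert-butyl)phenyl group, which a plain phenyl or a lone tert-butyl on this carbon would help to separate. From the compounds shown here alone, the effect of an amine or a carboxylic acid at the same carbon also remains open.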